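Compound 1 to compound 4: a swap of aromatic substituent

The source may report more compounds than this note shows. Statements on the series, on what has been measured and on what is new or still open speak of the compounds shown alone.

In a physicochemical assay for solubility, read by LC-MS, in phosphate buffer, with a stated time of 24 h, at pH 7.4 (a higher number here means a more soluble compound, a lower number a less soluble compound), compound 1 `Cc1nc(CO)ccc1-c1cnc(NCc2c(F)ccc3c2CCO3)c2cn[nH]c(=O)c12` gives 3000 nM, the lowest of the three numbers in hand. Compound 3 `CC1(C)CC(=O)N(c2cnc(NCc3c(F)ccc4c3CCO4)n3cnnc23)C1` gives 57000 nM and compound 2 `COCCC(=O)Nc1cnc(NCc2c(F)ccc3c2CCO3)n2cnnc12` gives 980000 nM, and both lie beyond the scatter from compound 1.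

Compound 4 `Cc1cc(-c2cnc(NCc3c(F)ccc4c3CCO4)c3cn[nH]c(=O)c23)n(C)n1` keeps the core of compound 1 and changes one group: 1,3-dimethyl-1H-pyrazol-5-yl in place of 6-(hydroxymethyl)-2-methylpyridin-3-yl on an aromatic carbon. In words, 1,3-dimethyl-1H-pyrazol-5-yl stands in place of 6-(hydroxymethyl)-2-methylpyridin-3-yl on an aromatic carbon.

Among the measured compounds shown here, only one measured step exists: a 17-fold lower number from compound 2 to compound 3 (1.24 log units; beyond the scatter). It is large and beyond the scatter, but it exchanges other groups on the core shared by compound 2 and compound 3, which is not the core of compound 1. It shows that a single exchange in this set can move the number a long way, yet it gives no direction for the present swap. For the measured compounds named here, no measured pair tests this aromatic group.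

With compound 1 at 3000 nM, the bottom of the numbers seen so far, a modest upward move is the working expectation, with wide uncertainty. The expected change is a 2.3-fold higher number from compound 1 to compound 4 (0.37 log units; beyond the scatter), close to the scatter and well short of the measured step. The estimate for compound 4 is 7000 nM, with an expected range of 1500 nM to 30000 nM.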

Compound 4, solubility: 1000 nM
Beside the measured number, compound 4's estimate is 7.0-fold (0.85 log units) above it; the measured number lies below the stated range.
By their numbers in this assay, from the lowest: compound 4; then compound 1; then compound 3; then compound 2.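

This aromatic carbon on the core of compound 1 now has its first measured exchange: in this assay, 1,3-dimethyl-1H-pyrazol-5-yl in place of 6-(hydroxymethyl)-2-methylpyridin-3-yl gives a 3.0-fold lower number from compound 1 to compound 4 (0.48 log units; beyond the scatter) and so places the lowest number of the set on this core. The step is modest, but it shows that the number responds to the group at this position, and for this swap the direction is downward. The swap changes several counted features at once, going from a six-membered to a five-membered aromatic ring, from 1 hydrogen-bond donor to 0 and from 9 heavy atoms to 7, and no evidence in hand separates them.

Still open, on these data alone, is how much of the step belongs to the hydroxymethyl group itself, which a carboxylic acid or an aminomethyl group in its place on the same 2-methylpyridin-3-yl would begin to test. Also open is whether any group at this position can lift the core of compound 1 above the number of compound 1, with only these two groups shown here.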